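Cyclohexyl in place of cyclopentyl: compound 3 to compound 4

This account rests on a few compounds, and the source may have more. Where it says the series, first, only, none or still open, it means among the compounds named here.

Measured in a functional assay on MCF7 cells (Homo sapiens) for inhibition, read by sulforhodamine B assay, with a stated time of 48 h; on this read-out lower numbers stand for stronger inhibition of growth and higher numbers for weaker inhibition of growth:
compound 1 `c1cc2c(cc1NC1=NCCO1)CCC2`: 9100 nM
compound 2 `c1ccc2cc(NC3=NCCO3)ccc2c1`: 4500 nM
compound 3 `c1cc(NC2=NCCO2)cc(OC2CCCC2)c1`: 62100 nM

Compound 3 stands highest of the three at 62100 nM, and its gaps to compound 1 and compound 2 both lie beyond the scatter. Next in the series is compound 4 `c1cc(NC2=NCCO2)cc(OC2CCCCC2)c1`, which carries cyclohexyl in place of cyclopentyl on an oxygen on an aromatic ring. Going by the values given here, no measured pair shows a change of this kind, so the data offer no direct guide to its size. The expectation is anchored on compound 3 at 62100 nM. In this assay, no step beyond the scatter is expected, with a slight lean towards a lower number. The expected change is a 1.4-fold lower number from compound 3 to compound 4 (0.14 log units; within the scatter). The estimate for compound 4 is 45000 nM, with an expected range of 18000 nM to 100000 nM.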

Compound 4, concentration for 50% growth inhibition: 15900 nM
The estimate for compound 4 lay 2.8-fold (0.45 log units) above the measured number, outside the stated range (below it).
By their numbers in this assay, from the lowest: compound 2; then compounds 1 and 4 (each within the scatter of the next); then compound 3.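

Working notes on the group on an oxygen on an aromatic ring: this position is sensitive to ring size, since in this assay cyclohexyl in place of cyclopentyl gives a 3.9-fold lower number from compound 3 to compound 4 (0.59 log units; beyond the scatter), a modest step but one beyond the scatter. The swap adds a single carbon to an all-carbon ring, with neither group carrying a hydrogen-bond donor, a hydrogen-bond acceptor or a net charge, so even a change this small registers here. Nothing at hand explains the step.

A single pair cannot show whether the lower number continues with a cycloheptyl group or depends on a ring at all, as an open chain such as n-hexyl would test. Also open, from the compounds shown here alone, is how a ring bearing a heteroatom, such as tetrahydropyranyl or piperidinyl, would behave on the same oxygen.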